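Working notes: moving the trifluoromethyl group

A few compounds are considered here, and "the series" means these few. Any claim that something is new, unique, unknown or untested is made for them only; others in the source may bear on it.

compound 1 (`COc1cc2ncnc(Nc3ccc(NC(=O)c4cccc(F)c4)cc3)c2cc1OC`) gives 13600 nM in a functional assay on MCF7 cells (Homo sapiens) for inhibition, read by MTT assay; on this read-out lower numbers stand for stronger inhibition and higher numbers for weaker inhibition
compound 2 (`COc1cc2ncnc(Nc3ccc(NC(=O)c4cccc(Cl)c4)cc3)c2cc1OC`) gives 18000 nM in this assay
compound 3 (`COc1cc2ncnc(Nc3ccc(NC(=O)c4cccc(C(F)(F)F)c4)cc3)c2cc1OC`) gives > 100000 nM as a limit in this assay

For compound 3, > 100000 nM is a limit and not a number. The change to compound 4 (`COc1cc2ncnc(Nc3ccc(NC(=O)c4ccc(C(F)(F)F)cc4)cc3)c2cc1OC`) is 4-(trifluoromethyl)phenyl in place of 3-(trifluoromethyl)phenyl on a carbonyl carbon. Both an at least 7.3-fold higher number from compound 1 to compound 3 (0.86 log units; beyond the scatter) and an at least 5.5-fold higher number from compound 2 to compound 3 (0.74 log units; beyond the scatter) bear on it and lie beyond the scatter. Neither moves the trifluoromethyl group, so they size this step only loosely. A step toward a lower number in this assay is expected, with a further limit still possible. The expected step is an at least 2.5-fold lower number from compound 3 to compound 4 (0.39 log units; beyond the scatter) and remains an estimate. Compound 4 is estimated at 40000 nM with a range from 12000 nM to 100000 nM as the expected span.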

Compound 4, half-maximal inhibitory concentration: > 100000 nM
Compound 4 gave a limit, no number; the forecaster's own chance of this, stated with the estimate: 40%; at least 2.5-fold (0.39 log units) between middle value and limit.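

In this assay compound 4 gives a limit, not a number, so the change to 4-(trifluoromethyl)phenyl brings no visible gain, and the step from compound 3 cannot be read: the limit of > 100000 nM in this assay, at which 2 of the 4 values shown sit.
Compound 4 shows an at least 5.5-fold higher number from compound 2 to compound 4 (0.74 log units; beyond the scatter) and an at least 7.3-fold higher number from compound 1 to compound 4 (0.86 log units; beyond the scatter) as well, so in these compounds the gap to the halogen compounds holds at both trifluoromethyl placements.

On these data alone, how the two trifluoromethyl isomers rank remains open. So does whether a nitrile or an amine in place of trifluoromethyl on the same aromatic carbon would give readable numbers.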